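Pyridin-2-yl to 1H-Pyrazol-1-yl: Expected Solubility of Compound 4

A few compounds are considered here, and "the series" means these few. Any claim that something is new, unique, unknown or untested is made for them only; others in the source may bear on it.

Measured so far:
Compound 1 `Cc1cc(C(=O)NNS(=O)(=O)c2ccccc2F)cc(-c2ccccn2)c1`: in a physicochemical assay for solubility, read by nephelometry, measured as kinetic solubility, at pH 2 (on this read-out lower numbers stand for lower solubility and higher numbers for higher solubility), compound 1 gives > 100 ug/mL, which is a limit of the assay rather than a number (the limit of > 100 ug/mL in this assay, at which 1 of the 3 values shown sits).
Compound 2 `Cc1cc(C(=O)NNS(=O)(=O)c2ccccc2F)cc(-n2cccn2)c1`: compound 2 gives 12.5 ug/mL.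
Compound 3 `O=C(NNS(=O)(=O)c1ccccc1F)c1cccc(-c2ccccn2)c1`: compound 3 gives 50 ug/mL.

Compound 4 `O=C(NNS(=O)(=O)c1ccccc1F)c1cccc(-n2cccn2)c1` has not yet been measured. It differs from compound 3 by 1H-pyrazol-1-yl in place of pyridin-2-yl on an aromatic carbon. The same change, taken once before from compound 1 to compound 2, is 1H-pyrazol-1-yl in place of pyridin-2-yl on an aromatic carbon, and there it gave an at least 8.0-fold lower number from compound 1 to compound 2 (0.90 log units; beyond the scatter). The cores of the two pairs differ by hydrogen in place of methyl on an aromatic carbon, a step of an at least 2.0-fold lower number from compound 1 to compound 3 (0.30 log units; that floor lies within the scatter). The surroundings of the change are not identical: in the first pair the place is also meta to a methyl group (1 heavy atom), so the two changes are the same kind of change rather than the same.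

For compound 4 a step of about an 8.3-fold lower number from compound 3 to compound 4 (0.92 log units; beyond the scatter) is expected, resting on the earlier step of an at least 8.0-fold lower number from compound 1 to compound 2 (0.90 log units; beyond the scatter) and on the value of compound 3, 50 ug/mL. The estimate for compound 4 is 6 ug/mL, expected to fall between 2 ug/mL and 20 ug/mL.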

Compound 4, solubility: 50 ug/mL
Beside the measured number, compound 4's estimate is 8.3-fold (0.92 log units) below it; measured number above the stated range.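

In this assay, the change that gave an at least 8.0-fold lower number from compound 1 to compound 2 (0.90 log units; beyond the scatter) on the core of compound 1 gives no change at the digits printed from compound 3 to compound 4 (within the scatter) on the core of compound 3, so its size did not carry from one core to the other in these two pairs. With 1H-pyrazol-1-yl in place, hydrogen in place of methyl gives a 4.0-fold higher number from compound 2 to compound 4 (0.60 log units; beyond the scatter), which means the effect of the swap and the presence of the methyl cannot simply be added together across these four compounds. This does not show why the two cores differ, and it cannot fix the true size of the first step, because that step rests on a limit of the assay for compound 1: the limit of > 100 ug/mL in this assay, at which 1 of the 4 values shown sits.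

The compounds shown leave open how the swap would behave with a chlorine or an ethyl group in the place of the methyl. They also leave open whether a ring carrying an amine or a carboxylic acid in the place of these two rings would follow either pair.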